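This account rests on a few compounds, and the source may have more. Where it says the series, first, only, none or still open, it means among the compounds named here.

Measured so far:
- compound 1, `COc1ccc(N(C)c2nc(C)nc3ccccc23)cc1OCCC[Se]C#N` — 799 nM
- compound 2, `C[Se]c1ccc(N(C)c2nc(C3CC3)nc3ccccc23)cc1` — 21 nM
- compound 3, `COc1ccc(N(C)c2nc(C)nc3ccccc23)cc1OCCCCCC[Se]C#N` — 1540 nM

All three were run in a functional assay on RKO cells (Homo sapiens) for inhibition, read by MTT assay, with a stated time of 48 h; on this read-out lower numbers stand for stronger inhibition and higher numbers for weaker inhibition. Compound 3 gives the highest number of the three; its nearest neighbour is compound 1, and the step of a 1.9-fold higher number from compound 1 to compound 3 (0.28 log units; within the scatter) shows that lengthening the chain carrying the selenocyanate changes little. For the measured compounds named here, compound 2 stands far below, but it differs from compound 3 in more than one place, so no single step is tied to it.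

Compound 4, `COc1ccc(N(C)c2nc(C)nc3ccccc23)cc1[Se]C`, is not yet measured. It differs from compound 3 as follows: a group of 2 heavy atoms (1 carbon, 1 selenium; no ring) in place of a group of 10 heavy atoms (7 carbon, 1 nitrogen, 1 oxygen, 1 selenium; no ring), on an aromatic carbon. Going by the values given here, no measured step covers this change directly. Among the compounds with values here, the only step available, between compound 1 and compound 3, concerns chain length and is within the scatter, so it gives no guidance on removing the chain altogether. What the numbers show is that compound 2, which carries a methyl on selenium bound directly to the ring, gives 21 nM, far below compound 3.

On that basis compound 4 is expected to move down, with an estimated step of a 10-fold lower number from compound 3 to compound 4 (1.01 log units; beyond the scatter). The estimate for compound 4 in this assay is 150 nM, with a range of 30 nM to 800 nM.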

Compound 4, half-maximal inhibitory concentration: 11 nM
The estimate for compound 4 lay 14-fold (1.13 log units) above the measured number; measured number below the stated range.
By their numbers in this assay, from the lowest: compounds 4 and 2 (each within the scatter of the next); then compounds 1 and 3 (each within the scatter of the next).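

In this assay, the aromatic carbon ortho to a methoxy group proves highly sensitive to the group it carries: the swap to a methyl on selenium gives a 140-fold lower number from compound 3 to compound 4 (2.15 log units; beyond the scatter), and from the shorter chain it gives a 73-fold lower number from compound 1 to compound 4 (1.86 log units; beyond the scatter). Lengthening the chain had changed little, so these results show something the chain pair could not: a large change appears only when the whole oxygen-linked selenocyanate chain gives way to selenium bound directly to the ring. Nothing available explains the size of these steps.

The swap removes the chain, its oxygen and the nitrile and moves selenium onto the ring all at once, so the compounds shown cannot separate these changes. Open, as far as these compounds go, is whether a methylthio group or a selenocyanate bound directly to the ring at this carbon would give a number near that of compound 4.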